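The compounds below may be only part of what the source reports. "The series", "measured", "known", "first", "only" and "open" are said of these compounds alone.

- Compound 1 `COc1cc(-c2nc(N(C)C)sc2-c2ccc3ccccc3c2)cc(OC)c1OC` gives 729 nM
- Compound 2 `COc1cc(-c2nc(N(C)C)sc2-c2ccc(C)cc2)cc(OC)c1OC` gives 3920 nM

Among the compounds with values here, in a functional assay on HT-29 cells (Homo sapiens) for antiproliferative activity, read by MTT assay, with a stated time of 72 h (on this read-out lower numbers stand for stronger inhibition and higher numbers for weaker inhibition), compound 2 stands at 3920 nM and holds the higher of the two numbers, which makes it the weaker inhibitor, while compound 1 sits on the stronger side at 729 nM and is its only neighbour.

Compound 3 `COc1cc(-c2nc(N(C)C)sc2-c2ccc(C(F)(F)F)cc2)cc(OC)c1OC` has not been measured yet. It differs from compound 2 by a single change trifluoromethyl in place of methyl on an aromatic carbon.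

Within the data shown here, only one measured step bears on this, and only loosely. The step of a 5.4-fold higher number from compound 1 to compound 2 (0.73 log units; beyond the scatter) is modest, and it also exchanges a group on an aromatic carbon, 4-methylphenyl in place of naphthalen-2-yl. The change to compound 3 replaces only the methyl and leaves the ring in place. Among the measured compounds shown here, no measured pair shows this exchange, so the data give no direction. A step smaller than that modest one is therefore expected in this assay and may well stay within the scatter.

The expected step is small (estimated as a 1.0-fold higher number from compound 2 to compound 3 (0.01 log units; within the scatter)) and could fall either way. Compound 3 is expected at 4000 nM (estimated range 1300 nM to 12000 nM).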

Compound 3, half-maximal inhibitory concentration: > 10000 nM
Compound 3 gave a limit, no number; the forecaster's own chance of this, stated with the estimate: 10%; middle value at least 2.5-fold (0.39 log units) away from the limit.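

In this assay compound 3 gives a limit and not a number: the limit of > 10000 nM in this assay, at which 1 of the 3 values shown sits.

Within the data shown here, the earlier compounds showed only that exchanging a whole ring system moves the read-out, whereas this result shows that a change at this one spot, para to a large group, matters with the ring left in place: trifluoromethyl in place of methyl gives an at least 2.5-fold higher number from compound 2 to compound 3 (0.40 log units; beyond the scatter), and that step is a lower bound, so the true step may be larger. The distance to the naphthalen-2-yl compound also widens, with an at least 13-fold higher number from compound 1 to compound 3 (1.13 log units; beyond the scatter), so among these three compounds, both para-substituted phenyl compounds lie on the weaker side of compound 1, and the methyl group is the better of the two substituents seen here.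

How far compound 3 really lies from compound 2 stays unknown, and the data give no reason for the loss. As far as these compounds go, whether a chlorine atom, a methoxy group or an amine at the same spot would behave like methyl or like trifluoromethyl also stays open.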